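A few compounds are considered here, and "the series" means these few. Any claim that something is new, unique, unknown or untested is made for them only; others in the source may bear on it.

Three compounds of the series have been run in a functional assay on the whole organism (strain Wistar) for inhibition, with Rattus norvegicus as the target, read by paw edema, with stated times of 30 min and 60 min, at a dose of 50 mg/kg by the oral route; a higher number here means more inhibition at the dose given (going by the name of the read-out), a lower number less inhibition. Compound 2 `Cc1ccc(C2=NNC(c3cn(-c4ccccc4)nc3-c3ccc(Cl)c(Cl)c3)C2)cc1` gives 56.5%. Compound 1 `Cc1ccc(C2=NN(c3ccc([N+](=O)[O-])cc3)C(c3cn(-c4ccccc4)nc3-c3ccc(Cl)c(Cl)c3)C2)cc1` carries 4-nitrophenyl in place of hydrogen on an amine nitrogen in a ring on the shared core, and in this assay compound 1 gives 72.5%, the step being a number 16 percentage points higher from compound 2 to compound 1 (beyond the scatter). Compound 3 `Fc1ccc(C2=NNC(c3cn(-c4ccccc4)nc3-c3ccc(Cl)c(Cl)c3)C2)cc1` differs from compound 2 by fluoro in place of methyl on an aromatic carbon; in this assay compound 3 gives 40.5%, the step being a number 16 percentage points lower from compound 2 to compound 3 (beyond the scatter). Compound 3 thus stands lowest of the three measured numbers.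

Compound 4 `O=[N+]([O-])c1ccc(N2N=C(c3ccc(F)cc3)CC2c2cn(-c3ccccc3)nc2-c2ccc(Cl)c(Cl)c2)cc1` has not been measured. Against compound 3 it carries 4-nitrophenyl in place of hydrogen on an amine nitrogen in a ring. The same kind of change has been made once before, from compound 2 to compound 1, with a number 16 percentage points higher from compound 2 to compound 1 (beyond the scatter). The two places are not identical: in compound 4 the ring atom two ring bonds away bears a 4-fluorophenyl group, in compound 1 a 4-methylphenyl group, so the change is of the same kind, not the same. The cores differ by the exchange already described between compound 2 and compound 3.

Among the compounds with values here, a step of about the same size is expected from compound 3 to compound 4, a number 14.5 percentage points higher from compound 3 to compound 4 (beyond the scatter), resting on the single prior step a number 16 percentage points higher from compound 2 to compound 1 (beyond the scatter). Compound 4 is therefore estimated at 55%, within 42% to 68%.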

Compound 4, a percentage reported as inhibition, in the whole organism at one dose (the size of the read-out at that dose, not a potency): 60.3%
The estimate for compound 4 lay 5.3 percentage points below the measured number, and the stated range covers the measured number.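

In this assay, 4-nitrophenyl in place of hydrogen on the amine nitrogen in a ring gives a number 19.8 percentage points higher from compound 3 to compound 4 (beyond the scatter), and the step carries over from the core with the 4-methylphenyl group to the core with the 4-fluorophenyl group: the same change on two cores in this assay, a number 16 percentage points higher (beyond the scatter) from compound 2 to compound 1 and a number 19.8 percentage points higher (beyond the scatter) from compound 3 to compound 4, 3.8 percentage points apart, within the scatter of two such steps. The reverse reading holds as well, since fluoro in place of methyl on an aromatic carbon gives a number 12.2 percentage points lower from compound 1 to compound 4 (beyond the scatter) with 4-nitrophenyl present, matching the step seen with hydrogen on that nitrogen: the same change on two cores in this assay, a number 16 percentage points lower (beyond the scatter) from compound 2 to compound 3 and a number 12.2 percentage points lower (beyond the scatter) from compound 1 to compound 4, 3.8 percentage points apart, within the scatter of two such steps. Across these four compounds the two changes therefore behave as separate increments, but this rests on a single square of compounds at one dose, gives no potency and does not explain either step.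

The compounds shown leave open whether an unsubstituted phenyl, an acetyl group or a longer alkyl chain on that nitrogen would give a step of similar size. On these data alone, it also remains open whether the same holds when methyl or fluoro is replaced by methoxy or an amine.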